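This account rests on a few compounds, and the source may have more. Where it says the series, first, only, none or still open, it means among the compounds named here.

Measured compounds:
- compound 1, `CC(C)S(=O)(=O)NC(=O)c1ccc(Nc2nc(NC3(c4ccc(Cl)cc4)CC3)nc(OCC(F)(F)F)n2)cc1`: 100%
- compound 2, `CC(C)NCCS(=O)(=O)NC(=O)c1ccc(Nc2nc(NC3(c4ccc(Cl)cc4)CC3)nc(OCC(F)(F)F)n2)cc1`: 89%
- compound 3, `CC(C)(C)NC(=O)NCCS(=O)(=O)NC(=O)c1ccc(Nc2nc(NC3(c4ccc(Cl)cc4)CC3)nc(OCC(F)(F)F)n2)cc1`: 96%

All three share one core and differ only in the group on the sulfonyl sulfur. In an ADME assay on microsomes from liver (Homo sapiens) for metabolic stability, with a stated time of 10 min (a higher number here means that more of the compound is left, a lower number that less of the compound is left), compound 1 gives 100%, compound 2 gives 89% and compound 3 gives 96%. Compound 2 holds the lowest of the three numbers: its gap to compound 3 stays within the scatter, a number 7 percentage points higher from compound 2 to compound 3 (within the scatter), while its gap to compound 1 lies beyond it, a number 11 percentage points lower from compound 1 to compound 2 (beyond the scatter).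

Compound 4, `CN(C)S(=O)(=O)NC(=O)c1ccc(Nc2nc(NC3(c4ccc(Cl)cc4)CC3)nc(OCC(F)(F)F)n2)cc1`, has not been measured. Relative to compound 2 the change is dimethylamino in place of 2-(isopropylamino)ethyl on a sulfonyl sulfur.

Among the compounds with values here, two measured steps bear on this. Going from the isopropyl of compound 1 to the longer chain of compound 2 cost a modest amount, a number 11 percentage points lower from compound 1 to compound 2 (beyond the scatter), whereas the chain of compound 3 cost nothing outside the scatter, a number 4 percentage points lower from compound 1 to compound 3 (within the scatter). Compound 4 takes the chain away again and puts a small dimethylamino in its place, which in size is closer to the isopropyl of compound 1 than to the chain of compound 2. The number for compound 4 is therefore expected to move back up by a small step, a number 7 percentage points higher from compound 2 to compound 4 (within the scatter), which may or may not exceed the scatter. The estimate for compound 4 is 96%, with a range from 86% to 100%.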

Compound 4, percent of the compound remaining: 86%
The estimate for compound 4 lay 10 percentage points above the measured number, and the stated range covers the measured number.
By their numbers in this assay, from the lowest: compounds 4, 2, 3 and 1 (each within the scatter of the next, the first and the last beyond it).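

In this assay, dimethylamino on the sulfonyl sulfur does not match isopropyl, even though it is the smaller of the replacements, and the step is beyond the scatter and modest (a number 14 percentage points lower from compound 1 to compound 4 (beyond the scatter)). Against the longer groups, the steps stay within the scatter, both for 2-(isopropylamino)ethyl (a number 3 percentage points lower from compound 2 to compound 4 (within the scatter)) and for 2-(((tert-butyl)carbamoyl)amino)ethyl (a number 10 percentage points lower from compound 3 to compound 4 (within the scatter)), so removing the chain does not by itself restore the level of compound 1, and the number at this position does not follow heavy-atom count across these four compounds. Nothing available here gives a reason for the separation between compound 1 and compound 4.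

Still open, going by these compounds, is whether that separation goes with any amine attached directly to the sulfonyl sulfur or only with dimethylamino, which methylamino, pyrrolidine or morpholine at the same place would help to separate. Also open, on these data alone, is how a plain ethyl, or a longer chain ending in a carboxylic acid, would compare with isopropyl and with the two chains already in hand.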